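The source may hold more compounds than are shown below. What is called first, only, known or untested is meant among the compounds shown, and "the series" means these compounds.

Working notes on the series. Potency is read in a functional assay on A-375 cells (Homo sapiens) for inhibition, with a stated time of 72 h; on this read-out higher numbers stand for weaker inhibition and lower numbers for stronger inhibition. Compound 1, `CC(C)[C@H]1CC[C@@]2(CO2)[C@H]2C(=O)OCC(C(=O)O)=C[C@H]12`, gives 1340 nM in this assay. Compound 3, `CNC(=O)C1=C[C@@H]2[C@@H](C(C)C)CC[C@@]3(CO3)[C@H]2C(=O)OC1`, gives 4150 nM in this assay. The change between them is methylamino in place of hydroxy on a carbonyl carbon, and it produced a 3.1-fold higher number from compound 1 to compound 3 (0.49 log units; beyond the scatter). Compound 2, `CC(C)[C@H]1CC[C@@](O)(CO)[C@H]2C(=O)OCC(C(=O)O)=C[C@H]12`, differs from compound 1 in its core; how the two cores differ is not broken down here. In this assay compound 2 reached only the limit > 32000 nM, which is a limit of the assay and not a number, the limit (the limit of > 32000 nM in this assay, at which 1 of the 3 values shown sits).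

Compound 4, `CNC(=O)C1=C[C@@H]2[C@@H](C(C)C)CC[C@@](O)(CO)[C@H]2C(=O)OC1`, is yet to be measured in this assay. It stands to compound 2 as compound 3 stands to compound 1: the change is methylamino in place of hydroxy on a carbonyl carbon, the same change at the same place, since the surroundings of the carbonyl carbon are described identically in both pairs. On the core of compound 1 this change gave a 3.1-fold higher number from compound 1 to compound 3 (0.49 log units; beyond the scatter); if the same direction holds on the core of compound 2, a step that the limit leaves unreadable from compound 2 to compound 4 is expected from compound 2 to compound 4, resting on the measured step from compound 1 to compound 3 and on compound 2 already sitting at the limit > 32000 nM. Compound 4 is therefore estimated at 80000 nM, expected between 32000 nM and 250000 nM, most likely again reported only as a limit.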

Compound 4, half-maximal inhibitory concentration: > 32000 nM
Compound 4: no number, only a limit (the forecaster's own chance of this, stated with the estimate: 85%); the middle value lies beyond the limit too.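

No step can be read between compound 2 and compound 4, because both results are limits of the assay and not numbers: the limit of > 32000 nM in this assay, at which 2 of the 4 values shown sit. The compounds shown leave open whether methylamino in place of hydroxy on a carbonyl carbon acts on the core of compound 2 as it does on the core of compound 1.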